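Shortening the Sulfanyl Chain in a Disulfide Sulfoxide Series

This account rests on a few compounds, and the source may have more. Where it says the series, first, only, none or still open, it means among the compounds named here.

Of the compounds shown here, three have been measured in a functional assay on WHCO1 cells (Homo sapiens) for antiproliferative activity, read by MTT assay, with a stated time of 48 h; on this read-out lower numbers stand for stronger inhibition and higher numbers for weaker inhibition. Compound 1 `C=CCSS/C=C/C[S+]([O-])CCCO` gives 27000 nM in this assay, compound 2 `CCCSS/C=C/C[S+]([O-])CCC` gives 24000 nM, and compound 3 `CCCSS/C=C\C[S+]([O-])CCC` gives 18000 nM. Compound 2 stands second highest of the three numbers; its nearest neighbour is compound 1 and its furthest is compound 3, yet all three lie within the scatter of one another. For the measured compounds named here, the single one-place step measured so far, a 1.3-fold lower number from compound 2 to compound 3 (0.12 log units; within the scatter), lies within the scatter; the two compounds share every atom and bond, and the fact that one of compounds 2 and 3 is drawn with a defined configuration and the other without, at the place where they differ is the only thing that sets them apart.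

Compound 4 `CCC[S+]([O-])C/C=C/SSC` has not yet been measured. It differs from compound 2 by hydrogen in place of ethyl on a saturated chain carbon bound to a sulfur, which, cut one bond further out, reads propylsulfanyl to methylsulfanyl. Going by the values given here, no measured step touches this part of the molecule, so the one step in hand has no direct bearing on the change, and the data point in neither direction. Compound 4 is therefore expected to give 25000 nM in this assay, with a range from 10000 nM to 60000 nM. That expectation amounts to a 1.0-fold higher number from compound 2 to compound 4 (0.02 log units; within the scatter), a step expected to stay within the scatter.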

Compound 4, half-maximal inhibitory concentration: 28000 nM
For compound 4 the middle estimate is 1.1-fold (0.05 log units) below the measured one, and the stated range covers the measured number.
By their numbers in this assay, from the lowest: compounds 3, 2, 1 and 4 (each within the scatter of the next).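

For the compounds shown here, the first measured change on this side of the molecule, hydrogen in place of ethyl on a saturated chain carbon bound to a sulfur, reads in this assay as a 1.2-fold higher number from compound 2 to compound 4 (0.07 log units; within the scatter). Cutting propylsulfanyl back to methylsulfanyl therefore leaves the number within the scatter, so this pair gives no sign that the ethyl part of the chain counts for this read-out, although the pair speaks only for this one shortening on the shared core of compound 2. Nothing on record gives a cause for this result, and the one available observation concerns a different part of the molecule.

Going by these compounds, whether a longer chain such as hexylsulfanyl, or a chain ending in an amine or a carboxylic acid, would move the number beyond the scatter remains open, and so does whether a phenyl group at this place would leave it unchanged. Also open, on these data alone, is whether the same shortening would read alike on the Z double bond of compound 3, which the present pair cannot tell.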